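The source may hold more compounds than are shown below. What is called first, only, known or untested is meant among the compounds shown, and "the series" means these compounds.

Compound 1 `CC/C=C\C[C@H]1C(=O)C=C[C@H]1CC(=O)OCCC`: 23000 nM
Compound 2 `CC/C=C\C[C@H]1C(=O)C=C[C@H]1CC(=O)OCCCC`: 23000 nM
Compound 3 `CC/C=C\C[C@H]1C(=O)C=C[C@H]1CC(=O)OCCOCCO`: 36000 nM

These three compounds were tested in a functional assay on RAW264.7 cells (Mus musculus) for inhibition, read by ELISA, with a stated time of 24 h; on this read-out higher numbers stand for an effect only at larger amounts of compound and lower numbers for an effect already at smaller amounts. Compound 3 gives 36000 nM, which lies within the scatter of the other two values, so the three cannot be ranked. Compound 4 `CC/C=C\C[C@H]1C(=O)C=C[C@H]1CC(=O)OCCOCCOCCO` differs from compound 3 by one change: 2-hydroxyethyl in place of hydrogen on an oxygen on a saturated carbon. In words, this is 2-hydroxyethyl in place of hydrogen on an oxygen on a saturated carbon.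

Within the data shown here, no measured pair carries exactly this change. The closest evidence is the introduction of 2-hydroxyethoxy on the chain, seen in a 1.6-fold higher number from compound 1 to compound 3 (0.19 log units; within the scatter) and in a 1.6-fold higher number from compound 2 to compound 3 (0.19 log units; within the scatter). The chain extension shows no change at the digits printed from compound 1 to compound 2 (within the scatter). All three steps stay within the scatter, so no step beyond the scatter is expected in this assay for this further extension. The estimated step is a 1.1-fold higher number from compound 3 to compound 4 (0.02 log units; within the scatter). Compound 4 is expected at 38000 nM, with an estimated range from 20000 nM to 70000 nM.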

Compound 4, half-maximal effective concentration: 42000 nM
Compound 4: the middle estimate sits 1.1-fold (0.04 log units) below what was measured, and the stated range covers the measured number.
By their numbers in this assay, from the lowest: compounds 1, 2, 3 and 4 (each within the scatter of the next).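

In this assay, 2-hydroxyethyl in place of hydrogen on an oxygen on a saturated carbon gives a 1.2-fold higher number from compound 3 to compound 4 (0.07 log units; within the scatter), so extending the chain at this oxygen moves the number no further than the scatter. The earlier compounds shown here had tested only the 2-hydroxyethoxy group and the shorter chains; the larger 2-(2-hydroxyethoxy)ethoxy group gives a 1.8-fold higher number from compound 1 to compound 4 (0.26 log units; within the scatter) and a 1.8-fold higher number from compound 2 to compound 4 (0.26 log units; within the scatter), and so no step beyond the scatter has yet appeared at this position. No measurement at hand offers an explanation for the size of these steps.

The compounds shown leave open whether an amine or a carboxylic acid in place of the 2-hydroxyethyl would give a step beyond the scatter. They also leave open how a longer chain of the same repeating kind would read out, and what changes to the shared core would do.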